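The source may hold more compounds than are shown below. What is called first, only, known or untested is meant among the compounds shown, and "the series" means these compounds.

Measured compounds:
compound 1, `O=C(CCCCC#Cc1ccc(Cl)cc1)c1ncc(-c2ccccn2)o1`: 20 nM
compound 2, `CC(C)(C)OC(=O)Nc1ccc(C#CCCCCC(=O)c2ncc(-c3ccccn3)o2)cc1`: 23 nM

Both were tested in an assay for inhibition of Fatty-acid amide hydrolase 1 (Rattus norvegicus); on this read-out lower numbers stand for stronger inhibition and higher numbers for weaker inhibition. Compound 1 gives 20 nM. Compound 2 gives 23 nM. The two numbers lie within the scatter of each other: the step is a 1.2-fold higher number from compound 1 to compound 2 (0.06 log units; within the scatter), for (tert-butoxycarbonyl)amino in place of chloro on an aromatic carbon.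

Compound 3, `O=C(CCCCC#Cc1ccncc1)c1ncc(-c2ccccn2)o1`, has not yet been measured. It differs from compound 1 in one place: pyridin-4-yl in place of 4-chlorophenyl on a triple-bonded carbon. Among the measured compounds shown here, only one measured step concerns the same end of the molecule, and that is a 1.2-fold higher number from compound 1 to compound 2 (0.06 log units; within the scatter), which shows that exchanging the substituent on the terminal aromatic ring left the number where it was. For the measured compounds named here, replacing the ring itself with pyridin-4-yl is a different kind of change, and no measured pair shows its effect, so the expectation rests on the tolerance seen in that single step. On this evidence a modest move is expected for compound 3, a 2.0-fold higher number from compound 1 to compound 3 (0.30 log units; within the scatter), with wide uncertainty around it. Compound 3 is therefore estimated at 40 nM, with a range from 10 nM to 160 nM.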

Compound 3, inhibition constant: 150 nM
Compound 3: middle estimate off by 3.8-fold (0.57 log units), on the low side; low and high end bracket the measured number.
By their numbers in this assay, from the lowest: compounds 1 and 2 (each within the scatter of the next); then compound 3.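

In this assay, among the compounds shown here, the exchange at this position is the first in the set to move the number beyond the scatter (a 7.5-fold higher number from compound 1 to compound 3 (0.88 log units; beyond the scatter)). The earlier step (a 1.2-fold higher number from compound 1 to compound 2 (0.06 log units; within the scatter)) changed only the substituent on a six-membered aromatic ring of carbon only and stayed within the scatter, whereas this one replaces 4-chlorophenyl with pyridin-4-yl on the triple-bonded carbon, so the position is not indifferent to every exchange of the terminal aromatic group. The change takes the count from 0 hydrogen-bond acceptors to 1 hydrogen-bond acceptor and removes the chlorine, but no supporting measurement is available to account for the higher number.

The compounds shown cannot separate the effect of the ring nitrogen from that of losing the chlorine, since a plain phenyl group and a chlorinated pyridine ring do not appear among them. They also leave open how the number would respond to pyridin-3-yl or pyridin-2-yl at this position, or to a free amine or a carboxylic acid on the terminal ring.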